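A Methyl on the Ring Nitrogen of Compound 2

This account rests on a few compounds, and the source may have more. Where it says the series, first, only, none or still open, it means among the compounds named here.

Two compounds share the core of compound 1, `O=S(=O)(c1cccc(F)c1)c1cn(C2CCCNC2)c2ccccc12`, which in a functional assay on HeLa cells for agonist activity at 5-hydroxytryptamine receptor 6 (Homo sapiens), read by cAMP accumulation and immunoassay, with a stated time of 10 min (a lower number here means that less compound is needed, a higher number that more compound is needed for the effect), gives 56 nM. Compound 2, `O=S(=O)(c1cccc(F)c1)c1cn(C2CCNC2)c2ccccc12`, carries pyrrolidin-3-yl in place of piperidin-3-yl on the aromatic nitrogen, and in this assay compound 2 gives 68 nM. The step of a 1.2-fold higher number from compound 1 to compound 2 (0.08 log units; within the scatter) shows that the two numbers cannot be told apart. Compound 2 therefore holds the higher of the two numbers, yet only by a margin that the assay cannot resolve.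

Compound 3, `CN1CCC(n2cc(S(=O)(=O)c3cccc(F)c3)c3ccccc32)C1`, differs from compound 2 in a single place: methyl in place of hydrogen on an amine nitrogen in a ring. For the measured compounds named here, no measured step bears directly on this change, since the one step in hand exchanges one ring for another and leaves the amine hydrogen untouched. Going by the values given here, the data therefore offer no direction for the added methyl, and the one change seen so far stayed within the scatter. For compound 3 the step of a 1.2-fold higher number from compound 2 to compound 3 (0.07 log units; within the scatter) is expected, remaining within the scatter. In this assay compound 3 is estimated at 80 nM, with a range from 30 nM to 220 nM.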

Compound 3, half-maximal effective concentration: 398 nM
Estimate against measurement, compound 3: 5.0-fold (0.70 log units) below; measured number outside the range, above it.
By their numbers in this assay, from the lowest: compounds 1 and 2 (each within the scatter of the next); then compound 3.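

In this assay, for the compounds shown here, the amine nitrogen of the ring turns out to be a place that answers to a change: methyl in place of hydrogen there gives a 5.9-fold higher number from compound 2 to compound 3 (0.77 log units; beyond the scatter) and so moves the number beyond the scatter, which the exchange of one ring for another between the earlier compounds had not done. Read against the piperidin-3-yl compound, the 1-methylpyrrolidin-3-yl group gives a 7.1-fold higher number from compound 1 to compound 3 (0.85 log units; beyond the scatter) as well, so the two compounds with hydrogen on the amine nitrogen stay together while the methyl compound stands apart from both. Nothing available gives a reason for this rise in the number.

The compounds shown leave open whether the methyl would have a similar effect on the amine nitrogen of the piperidin-3-yl ring in compound 1, as the change is seen here on the five-membered ring alone. They also leave open how a longer chain such as ethyl or propyl, or a carbonyl-bearing group such as acetyl, would behave on that same nitrogen.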